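Carbamoyl Out, Propyl In: an Expected Drop in Concentration

The source may report more compounds than this note shows. Statements on the series, on what has been measured and on what is new or still open speak of the compounds shown alone.

Measured so far:
- Compound 1, `NC(=O)Cn1c(=O)n(C2OC(CO)[C@@H](O)[C@H]2O)c2nc(N)nc(O)c21`: in a functional assay (B cells) with Mus musculus as the target (on this read-out higher numbers stand for an effect only at larger amounts of compound and lower numbers for an effect already at smaller amounts), compound 1 gives 190 uM.
- Compound 2, `CCCn1c(=O)n(C2C=CC(CO)O2)c2nc(N)nc(O)c21`: in this assay compound 2 gives 6 uM.

Compound 1 stands highest of these two numbers. Compound 2 differs from it in more than one place, so that pair shows only its two values.

Compound 3, `CCCCn1c(=O)n(C2OC(CO)[C@@H](O)[C@H]2O)c2nc(N)nc(O)c21`, changes compound 1 in a single place: propyl in place of carbamoyl on a saturated chain carbon bound to an aromatic nitrogen. Compound 2, which also carries a propyl chain, gives 6 uM in this assay, a much lower number than compound 1. On that ground a downward step is expected, beyond the scatter, of about a 9.5-fold lower number from compound 1 to compound 3 (0.98 log units; beyond the scatter). For compound 3 the estimate is 20 uM, expected to fall between 5 uM and 80 uM.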

Compound 3, concentration for half-maximal effect: 11 uM
Compound 3: middle estimate off by 1.8-fold (0.26 log units), on the high side; the range from low to high includes it.
By their numbers in this assay, from the lowest: compounds 2 and 3 (each within the scatter of the next); then compound 1.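

Replacing carbamoyl with propyl on a saturated chain carbon bound to an aromatic nitrogen gives a 17-fold lower number from compound 1 to compound 3 (1.24 log units; beyond the scatter) in this assay. For the compounds shown here, this pair is the first direct read of this position, and it shows that the number responds strongly to what sits there while the rest of the molecule stays the same. The swap keeps the heavy-atom count but loses a hydrogen-bond donor and acceptor, and nothing measured here says why the number falls. As far as these compounds go, whether an amine, a carboxylic acid or a longer chain at this place would move the number further remains open.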